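A few compounds are considered here, and "the series" means these few. Any claim that something is new, unique, unknown or untested is made for them only; others in the source may bear on it.

Measured so far:
compound 1, `C/C=C/C(=O)N(Cc1ccc(OC)c([N+](=O)[O-])c1)c1cc(OC)c(OC)c(OC)c1`: 590 nM
compound 2, `CCC/C=C/C(=O)N(Cc1ccc(OC)c(O)c1)c1cc(OC)c(OC)c(OC)c1`: 70 nM

In a functional assay on MGC-803 cells (Homo sapiens) for inhibition, read by MTT assay, with a stated time of 48 h (on this read-out lower numbers stand for stronger inhibition and higher numbers for weaker inhibition), compound 1 gives 590 nM, while compound 2 gives 70 nM, the lowest of the two numbers; the gap from compound 1 to compound 2 lies beyond the scatter. Compounds 1 and 2 differ in more than one place, so their two values alone do not isolate any single change.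

Compound 3, `C/C=C/C(=O)N(Cc1ccc(OC)c(O)c1)c1cc(OC)c(OC)c(OC)c1`, is not yet measured. Relative to compound 2 it carries hydrogen in place of ethyl on a saturated chain carbon bound to a double-bonded chain carbon. For the measured compounds named here, no measured pair shows this change on its own, so its effect in this assay is unknown. The expectation is a modest step from compound 2 to compound 3 toward a higher number, a 1.9-fold higher number from compound 2 to compound 3 (0.27 log units; within the scatter), at the edge of the scatter rather than clearly beyond it. Compound 3 is estimated at 130 nM, with a range of 45 nM to 380 nM.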

Compound 3, half-maximal inhibitory concentration: 27 nM
Compound 3: middle estimate off by 4.8-fold (0.68 log units), on the high side, and the stated range ends above it.
By their numbers in this assay, from the lowest: compound 3; then compound 2; then compound 1.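

Notes on the series: in this assay, hydrogen in place of ethyl on a saturated chain carbon bound to a double-bonded chain carbon gives a 2.6-fold lower number from compound 2 to compound 3 (0.41 log units; beyond the scatter), so at this place the smaller prop-1-en-1-yl end reads better than the pent-1-en-1-yl end. Compound 3 also isolates the change on the aromatic carbon: hydroxy in place of nitro gives a 22-fold lower number from compound 1 to compound 3 (1.34 log units; beyond the scatter), the larger of the two steps. Nothing available accounts for either step.

From the compounds shown here alone, each change is seen only once, on a single background, so it remains open whether the two steps hold when combined differently. Also open, going by these compounds, are how a chain longer than pent-1-en-1-yl would read at the first place and how an amine would read on that aromatic carbon.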